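A few compounds are considered here, and "the series" means these few. Any claim that something is new, unique, unknown or untested is made for them only; others in the source may bear on it.

Working notes on the series. Compound 1 `COC(=O)C1=C(C)NC(=O)NC1c1cccs1` in an assay on membranes from HeLa cells for displacement of a labelled ligand from adenosine receptor A3 (Homo sapiens), read by scintillation counting, with a stated time of 180 min, tested at 1 uM (on this read-out higher numbers stand for more inhibition at the one concentration tested (going by the name of the read-out) and lower numbers for less inhibition), gives 3%. Compound 2 `CCCOC(=O)C1=C(C)NC(=O)NC1c1cccs1` differs from it by ethyl in place of hydrogen on a saturated chain carbon bound to an oxygen next to a carbonyl group; in this assay compound 2 gives 32%, and the step of a number 29 percentage points higher from compound 1 to compound 2 (beyond the scatter).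

Compound 3 `COC(=O)C1=C(C)NC(=S)NC1c1ccoc1` is built on a second core; the difference between the two cores is not broken down here. In this assay compound 3 gives 3%, level with compound 1 at the digits reported, the two together being the lowest of the three numbers.

Compound 4 `CCCOC(=O)C1=C(C)NC(=S)NC1c1ccoc1` is not yet measured. Relative to compound 3 it carries ethyl in place of hydrogen on a saturated chain carbon bound to an oxygen next to a carbonyl group, at the same place as in compound 2, so it is the same change, made twice among the four compounds. Among the compounds with values here, only one instance is measured, on the first core; the second core has no measured counterpart for it, which widens the range. Resting on compound 1 and compound 2 as the measured pair, the expected step is a number 22 percentage points higher from compound 3 to compound 4 (beyond the scatter), close to the earlier one. Compound 4 is therefore estimated at 25% in this assay, between 5% and 45%.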

Compound 4, a percentage reported as inhibition, at one concentration (the size of the read-out at that concentration, not a potency): 3%
Estimate against measurement, compound 4: 22 percentage points above; measured number below the stated range.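

Methoxycarbonyl to propoxycarbonyl does not carry over between the two cores in this assay, where the step on the core of compound 3 reads no change at the digits printed from compound 3 to compound 4 (within the scatter). Set beside the earlier step, the two differ: the same change on two cores in this assay, a number 29 percentage points higher (beyond the scatter) from compound 1 to compound 2 and no change at the digits printed (within the scatter) from compound 3 to compound 4, 29 percentage points apart, beyond the scatter of two such steps

So the rise seen on the core of compound 1 cannot be assumed on the core of compound 3, but each core rests on a single pair, and nothing here shows which part of the difference between the cores is responsible, or how the change would behave on any other core.

The compounds shown leave open how a longer chain such as butoxycarbonyl, or a carboxylic acid in place of the methoxycarbonyl, would read on either core. They also leave open how the two cores would compare if only one part of them were changed at a time.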